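The source may report more compounds than this note shows. Statements on the series, on what has been measured and on what is new or still open speak of the compounds shown alone.

Series notes. Compound 1 `CN(C)CCn1cnnc1-c1cc(Oc2ccc(NC(=O)N/N=C/c3cccc(O)c3)cc2F)ccn1` has no result in an ADME assay on WI-38 cells (Homo sapiens) for cytotoxicity, read by MTT assay, with a stated time of 72 h; on this read-out higher numbers stand for weaker inhibition and lower numbers for stronger inhibition; its entry there is "not determined" (no result reported), so compound 1 stands on no single number, as none was determined. Compound 2 `CN(C)CCn1cnnc1-c1cc(Oc2ccc(NC(=O)N/N=C/c3ccc(F)cc3Cl)cc2F)ccn1` is a close analogue sharing the core of compound 1. In this assay compound 2 gives 2090 nM. Compound 3 `CN(C)CCn1cnnc1-c1cc(Oc2ccc(NC(=O)N/N=C/c3cccc(Cl)c3Cl)cc2F)ccn1` differs from compound 1 by 2,3-dichlorophenyl in place of 3-hydroxyphenyl on a carbon with a double bond to nitrogen. For the measured compounds named here, no measured step links compound 1 and compound 3, so the size of the step in this assay is open; the expectation is a modest move toward lower numbers, that is stronger inhibition, of a size near the edge of the usual scatter. Compound 3 is expected to give 1500 nM in this assay, within 500 nM to 5000 nM.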

Compound 3, half-maximal inhibitory concentration: 6130 nM
Compound 3: middle estimate off by 4.1-fold (0.61 log units), on the low side; the whole stated range lies below it.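

In this assay, the position on the carbon with a double bond to nitrogen responds to an exchange between two halogen-bearing phenyl groups: 2,3-dichlorophenyl in place of 2-chloro-4-fluorophenyl gives a 2.9-fold higher number from compound 2 to compound 3 (0.47 log units; beyond the scatter), a shift toward weaker inhibition. Nothing available accounts for the size or direction of this step.

With no result for compound 1, the step from 3-hydroxyphenyl cannot be read. From the compounds shown here alone, how an amine or a carboxylic acid on this phenyl ring would read out remains open.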